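Moving a methyl between two sulfamoyl nitrogens

The compounds below may be only part of what the source reports. "The series", "measured", "known", "first", "only" and "open" are said of these compounds alone.

Of the compounds shown here, three on one shared core have been tested in a functional assay on the whole organism for inhibition, with Mus musculus as the target; on this read-out lower numbers stand for an effect already at smaller amounts and higher numbers for an effect only at larger amounts of compound. Compound 1 `CCN1CCCC1CNC(=O)c1cc(N(C)S(C)(=O)=O)c(C)cc1OC` gives 26.1 mg/kg in this assay. Compound 2 `CCN1CCCC1CNC(=O)c1cc(N(C)S(=O)(=O)N(C)C)c(C)cc1OC` reaches only the limit of this assay, > 50 mg/kg. Compound 3 `CCN1CCCC1CNC(=O)c1cc(NS(=O)(=O)NC)c(C)cc1OC` likewise reaches only the limit of this assay, > 50 mg/kg. Compound 3 therefore stands at the limit rather than at a number, a position it shares with one other compound (the limit of > 50 mg/kg in this assay, at which 2 of the 3 values shown sit).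

The step to compound 4 `CCN1CCCC1CNC(=O)c1cc(N(C)S(N)(=O)=O)c(C)cc1OC` is methyl(sulfamoyl)amino in place of (methylsulfamoyl)amino on an aromatic carbon; the two have the same atoms, joined differently, on an aromatic carbon of a six-membered aromatic ring of carbon only, ortho to a methyl group, meta to a large group, para to a methoxy group. Of the measured steps, an at least 1.9-fold higher number from compound 1 to compound 2 (0.28 log units; that floor lies within the scatter) and an at least 1.9-fold higher number from compound 1 to compound 3 (0.28 log units; that floor lies within the scatter) both run from a number to the limit, while a step that the two limits leave unreadable from compound 2 to compound 3. No measured neighbour of compound 4 gives a number, so the expected step of a number no higher from compound 3 to compound 4 (the limit leaves the size open) cannot be set beyond the scatter in either direction. Compound 4 is therefore estimated at 50 mg/kg, within 20 mg/kg to 150 mg/kg, most likely again a limit.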

Compound 4, dose for half-maximal effect: > 50 mg/kg
Compound 4 gave a limit, no number; the forecaster's own chance of this, stated with the estimate: 60%; the middle value lies on the limit itself.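

In this assay compound 4 also stays at a limit, > 50 mg/kg. Amino in place of methyl on a sulfonyl sulfur gives an at least 1.9-fold higher number from compound 1 to compound 4 (0.28 log units; that floor lies within the scatter). The steps among compound 2, compound 3 and compound 4 cannot be read, so moving the methyl between the two sulfamoyl nitrogens shows no direction on this read-out, and the limit now holds most of the set: the limit of > 50 mg/kg in this assay, at which 3 of the 4 values shown sit.

On these data alone, it remains open how far compound 2, compound 3 and compound 4 actually lie from compound 1, and whether any sulfamoyl group at this aromatic carbon gives a number at all. As far as these compounds go, it is also open whether ethyl in place of methyl on the sulfonyl sulfur, or a carboxylic acid on this aromatic carbon, would give a number or meet the same limit.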